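Phenyl to isopropyl beside the ester-bearing carbon

A few compounds are considered here, and "the series" means these few. Any claim that something is new, unique, unknown or untested is made for them only; others in the source may bear on it.

Compound 3 `COC(=O)[C@@H](NC(=O)c1[nH]cnc1C(=O)Nc1ccc(Cl)c(Cl)c1)c1ccccc1` gives 13200 nM in a functional assay on HL-60 cells (Homo sapiens), with a stated time of 2 days (a higher number here means a weaker inhibitor, a lower number a stronger inhibitor), the lowest of the two numbers shown; its nearest neighbour is compound 1 `COc1ccc(CNC(=O)c2[nH]cnc2C(=O)Nc2ccc(Cl)c(Cl)c2)cc1`, which gives 24300 nM, a gap that sits within the scatter. Compound 2 `COC(=O)[C@@H](C)NC(=O)c1[nH]cnc1C(=O)Nc1ccc(Cl)c(Cl)c1` reaches only a limit of the assay, > 62500 nM. Among the compounds with values here, the one measured step, an at least 2.5-fold higher number from compound 1 to compound 2 (0.41 log units; beyond the scatter), points toward weaker inhibition when the aromatic group on the amide-type nitrogen is exchanged for a small ester-bearing chain; it rests on a single value, and that value is a limit (the limit of > 62500 nM in this assay, at which 1 of the 3 values shown sits). Compound 4 `COC(=O)[C@@H](NC(=O)c1[nH]cnc1C(=O)Nc1ccc(Cl)c(Cl)c1)C(C)C` differs from compound 3 by isopropyl in place of phenyl on a saturated chain carbon bound to an amide-type nitrogen and a carbonyl carbon. Within the data shown here, no measured step matches this change exactly; compounds 2 and 3, which share the ester, show a limit for the methyl and a number for the phenyl. He therefore expects a modest weakening, a 2.7-fold higher number from compound 3 to compound 4 (0.42 log units; beyond the scatter), for compound 4, with an estimate of 35000 nM and a range from 14000 nM to 62500 nM.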

Compound 4, half-maximal inhibitory concentration: > 62500 nM
Compound 4 was reported as a limit; the forecaster's own chance of this, stated with the estimate: 35%; middle value at least 1.7-fold (0.25 log units) from the limit.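

At the saturated chain carbon bound to an amide-type nitrogen and a carbonyl carbon, phenyl and isopropyl are not interchangeable: in this assay, isopropyl in place of phenyl gives an at least 4.7-fold higher number from compound 3 to compound 4 (0.67 log units; beyond the scatter). Exchanging 4-methoxybenzyl on the amide-type nitrogen for 1-(methoxycarbonyl)-2-methylpropyl gives an at least 2.5-fold higher number from compound 1 to compound 4 (0.41 log units; beyond the scatter), so among the three ester compounds only compound 3, with phenyl, gives a number rather than a limit. The step from compound 2 to compound 4 cannot be read, and the sizes of the other steps ending at compound 4 are minimum sizes: the limit of > 62500 nM in this assay, at which 2 of the 4 values shown sit.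

From the compounds shown here alone, how much weaker compound 4 really is compared with compound 3 stays open. The compounds shown also leave open whether a benzyl at this carbon, or a carboxylic acid in place of the methyl ester, would keep the number of compound 3.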